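The source may hold more compounds than are shown below. What is called first, only, known or untested is meant among the compounds shown, and "the series" means these compounds.

Compound 1 `C=CCSc1nnc(-c2cc(OC)c(OC)c(OC)c2)n1N1C(=O)c2ccccc2C1=O`: in a functional assay on A549 cells (Homo sapiens) for cytotoxicity, read by MTT assay, with a stated time of 48 h (a higher number here means a weaker inhibitor, a lower number a stronger inhibitor), compound 1 gives > 200000 nM, which is a limit of the assay and not a number.
Compound 2 `C#CCSc1nnc(-c2cc(OC)c(OC)c(OC)c2)n1N1C(=O)c2ccccc2C1=O`: in this assay compound 2 gives > 200000 nM, again a limit of the assay.
Compound 3 `COc1cc(-c2nnc(SCC(=O)c3ccc(C)cc3)n2N2C(=O)c3ccccc3C2=O)cc(OC)c1OC`: in this assay compound 3 gives 6760 nM.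

All three share the same core and differ only in the group on a saturated chain carbon bound to a sulfur. For the measured compounds named here, compound 3 stands alone as the only compound with a real number; the other two values sit at the limit of > 200000 nM in this assay, at which 2 of the 3 values shown sit. The steps into it are large: an at least 29-fold lower number from compound 1 to compound 3 (1.47 log units; beyond the scatter) and an at least 29-fold lower number from compound 2 to compound 3 (1.47 log units; beyond the scatter), whereas a step that the two limits leave unreadable from compound 1 to compound 2.

Compound 4 `COc1cc(-c2nnc(SC)n2N2C(=O)c3ccccc3C2=O)cc(OC)c1OC` has not yet been measured. The change from compound 3 is hydrogen in place of (4-methylphenyl)carbonyl on a saturated chain carbon bound to a sulfur. This removes exactly the group that set compound 3 apart from compounds 1 and 2 and leaves a small substituent, much as vinyl and ethynyl are small. The two large steps into compound 3 therefore bear directly on this change, and a step of similar size back in the weaker direction is expected, a 22-fold higher number from compound 3 to compound 4 (1.35 log units; beyond the scatter). Compound 4 is accordingly expected near 150000 nM, in the range 30000 nM to 500000 nM, with a real chance that the assay reports only a limit.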

Compound 4, half-maximal inhibitory concentration: > 200000 nM
Compound 4 was reported as a limit; the forecaster's own chance of this, stated with the estimate: 55%; at least 1.3-fold (0.12 log units) between middle value and limit.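

In this assay taking away the (4-methylphenyl)carbonyl group and leaving only hydrogen on the chain carbon bound to the sulfur produces an at least 29-fold higher number from compound 3 to compound 4 (1.47 log units; beyond the scatter) and returns the compound to the limit of the assay. Compounds 1 and 2 left it possible that vinyl and ethynyl were themselves unfavourable, but compound 4 carries neither and still gives only a limit, so among these four compounds only the one with (4-methylphenyl)carbonyl gives a real number. The steps among compound 1, compound 2 and compound 4 cannot be read, and all three stop at the same limit: the limit of > 200000 nM in this assay, at which 3 of the 4 values shown sit.

Still open, going by these compounds, is whether the carbonyl or the aromatic ring matters more; a benzyl group would keep only the ring, and an acetyl group only the carbonyl. The role of the methyl on that ring is also untested by these compounds, and a plain benzoyl group would address it.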